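The source may hold more compounds than are shown below. What is called first, only, known or untested is meant among the compounds shown, and "the series" means these compounds.

This account follows one change to the amide of compound 1, `COCOc1cc(/C=C/C(=O)OCC(=O)NCc2ccco2)ccc1OCc1ccccc1`, which in a functional assay on HeLa cells (Homo sapiens) for cytotoxicity, read by MTT assay, with a stated time of 72 h (on this read-out higher numbers stand for weaker inhibition and lower numbers for stronger inhibition), returns > 200000 nM. That figure is a limit of the assay and not a number. Compound 1 therefore stands at the limit of > 200000 nM in this assay, at which 1 of the 2 values shown sits. A second compound, compound 2, `O=C(COC(=O)/C=C/c1ccc(O)c(O)c1)Nc1ccc(Cl)cc1`, has been measured in the same setting, and in this assay compound 2 gives 195000 nM. Going by the values given here, no step between measured compounds that differ in one place exists here, so the two values show only that both compounds inhibit weakly and do so to a similar degree.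

The compound now in question is compound 3, `COCOc1cc(/C=C/C(=O)OCC(=O)Nc2ccc(OC)cc2)ccc1OCc1ccccc1`. It differs from compound 1 in one place: 4-methoxyphenyl in place of (furan-2-yl)methyl on an amide-type nitrogen. Among the compounds with values here, nothing among the measured compounds tells how this exchange moves the read-out, and both compounds measured so far sit at the weak end of the scale. The step is therefore expected to be small, or none beyond the scatter, as a number no higher from compound 1 to compound 3 (the limit leaves the size open) states, with a fair chance that only a limit is reported again. Compound 3 is estimated at 200000 nM in this assay, within 100000 nM to 400000 nM.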

Compound 3, half-maximal inhibitory concentration: 155000 nM
Compound 3: middle estimate off by 1.3-fold (0.11 log units), on the high side; the measured number falls inside the stated range.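

Going by these compounds alone, with 4-methoxyphenyl in place of (furan-2-yl)methyl on the amide-type nitrogen, the read-out in this assay becomes a number for the first time, and the change reads as an at least 1.2-fold lower number from compound 1 to compound 3 (0.11 log units; that floor lies within the scatter), with its true size left open. The exchange of one aromatic ring on a one-carbon link for a larger, carbon-only aromatic ring set directly on the nitrogen therefore shows no weakening, yet compound 3 at 155000 nM still sits at the weak end of the scale. The starting point of the step is a limit and not a number, and it belongs to compound 1: the limit of > 200000 nM in this assay, at which 1 of the 3 values shown sits.

The compounds shown do not separate the part played by the methoxy group from that of the phenyl ring itself or of the lost one-carbon link. Nor do they say whether an amine on a longer chain or a carboxylic acid on this amide nitrogen, in place of 4-methoxyphenyl, would move the read-out beyond the scatter.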